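A few compounds are considered here, and "the series" means these few. Any claim that something is new, unique, unknown or untested is made for them only; others in the source may bear on it.

Within the data shown here, in a functional assay on HeLa cells (Homo sapiens) for antiproliferative activity, read by CCK-8 assay, with a stated time of 72 h, tested at 2 uM (a lower number here means a weaker effect, a higher number a stronger effect of the compound at the concentration tested), compound 3 `CN1CCN(C(=S)SCc2ccc(C(=O)Nc3ccccc3N)cc2)CC1` gives 52.6%, the lowest of the three numbers measured so far. Compound 2 `Nc1ccccc1NC(=O)c1ccc(CSC(=S)N2CCN(Cc3ccncc3)CC2)cc1` gives 59.5%, and compound 1 `N#Cc1ccc(N2CCN(C(=S)SCc3ccc(C(=O)Nc4ccccc4N)cc3)CC2)cc1` gives 71.6%. The step of a number 6.9 percentage points lower from compound 2 to compound 3 (within the scatter) lies within the scatter, whereas the step of a number 19 percentage points lower from compound 1 to compound 3 (beyond the scatter) is a modest one beyond it. Compound 4 `Nc1ccccc1NC(=O)c1ccc(CSC(=S)N2CCN(Cc3cccnc3)CC2)cc1` differs from compound 3 by pyridin-3-yl in place of hydrogen on a saturated chain carbon bound to an amine nitrogen in a ring. Among the measured compounds shown here, the measured step that bears on this change is the one between compound 2 and compound 3, where a pyridin-4-yl group at the same place was removed for a difference within the scatter; putting a pyridin-3-yl group there instead is expected to give only a small rise, a number 5.4 percentage points higher from compound 3 to compound 4 (within the scatter), in this assay. Compound 4 is therefore expected to reach 58%, in the range 47% to 69%.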

Compound 4, a percentage reported as inhibition, at one concentration (the size of the read-out at that concentration, not a potency): 69.7%
Estimate against measurement, compound 4: 11.7 percentage points below; the whole stated range lies below it.
By their numbers in this assay, from the lowest: compounds 3 and 2 (each within the scatter of the next); then compounds 4 and 1 (each within the scatter of the next).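

In this assay, the place on a saturated chain carbon bound to an amine nitrogen in a ring responds to which pyridinyl group it carries: pyridin-3-yl in place of hydrogen gives a number 17.1 percentage points higher from compound 3 to compound 4 (beyond the scatter), and pyridin-3-yl in place of pyridin-4-yl gives a number 10.2 percentage points higher from compound 2 to compound 4 (beyond the scatter). (Pyridin-3-yl)methyl in place of 4-cyanophenyl gives a number 1.9 percentage points lower from compound 1 to compound 4 (within the scatter), so the two groups cannot be told apart here. Nothing measured accounts for the gap between the two pyridinyl groups. The compounds shown leave open how pyridin-2-yl or plain phenyl would read at this place, and whether a longer chain carrying pyridin-3-yl would hold the number.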